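Methyl Swapped for Hydrogen on the Shared Core

The source may report more compounds than this note shows. Statements on the series, on what has been measured and on what is new or still open speak of the compounds shown alone.

Measured so far:
Compound 1, `COc1ccc2nc(-c3ccc(N/C=C\C(=O)c4ccc(OC)c(O)c4)c(C)c3)sc2c1`: 18000 nM
Compound 2, `COc1ccc2nc(-c3ccc(N/C=C\C(=O)c4cc(OC)c(OC)c(OC)c4)c(C)c3)sc2c1`: 11100 nM
Compound 3, `COc1ccc2nc(-c3ccc(N/C=C\C(=O)c4ccc(OC)c(O)c4)cc3)sc2c1`: 12800 nM

Of the compounds shown here, three have been tested in a functional assay on A549 cells (Homo sapiens) for antiproliferative activity, read by sulforhodamine B assay, with a stated time of 48 h; a higher number here means a weaker inhibitor, a lower number a stronger inhibitor. In this assay compound 1 gives 18000 nM, compound 2 gives 11100 nM and compound 3 gives 12800 nM. The three numbers all lie close to one another, and every gap between them is within the scatter, so none of the three can be called the stronger or weaker inhibitor.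

Compound 3 differs from compound 1 in one place: hydrogen in place of methyl on an aromatic carbon. This change gives a 1.4-fold lower number from compound 1 to compound 3 (0.15 log units; within the scatter). The difference between the core of compound 1 and the core of compound 2 is not broken down here.

Compound 4, `COc1ccc2nc(-c3ccc(N/C=C\C(=O)c4cc(OC)c(OC)c(OC)c4)cc3)sc2c1`, has not yet been measured. It differs from compound 2 by hydrogen in place of methyl on an aromatic carbon. The surroundings are not described word for word as for the earlier pair: in compound 4 the changed carbon is meta to a 6-methoxy-1,3-benzothiazol-2-yl group, whereas in compound 3 it is only given as meta to a large group, so the two changes are the same kind of change rather than the same.

Because compound 1 to compound 3 gave a 1.4-fold lower number from compound 1 to compound 3 (0.15 log units; within the scatter), compound 4 is expected to show a step of about a 1.2-fold lower number from compound 2 to compound 4 (0.09 log units; within the scatter) from compound 2, a change that would stay within the scatter. Compound 4 is therefore estimated at 9000 nM, most likely between 4000 nM and 20000 nM.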

Compound 4, half-maximal inhibitory concentration: 12100 nM
Estimate against measurement, compound 4: 1.3-fold (0.13 log units) below; the range from low to high includes it.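

In this assay, putting hydrogen in place of methyl on the aromatic carbon of compound 2 gives a 1.1-fold higher number from compound 2 to compound 4 (0.04 log units; within the scatter), so the swap leaves no readable mark on this core, and the two steps agree as far as the data can tell: the same change on two cores in this assay, a 1.4-fold lower number (0.15 log units; within the scatter) from compound 1 to compound 3 and a 1.1-fold higher number (0.04 log units; within the scatter) from compound 2 to compound 4, 1.5-fold (0.19 log units) apart, within the scatter of two such steps The simplest reading is that this change carries from one core to the other in a modest sense: on both cores shown, swapping methyl for hydrogen produces no step that can be told apart from ordinary repeat-to-repeat variation. This does not show that the methyl group is without any effect, since a small real effect could be hidden in the scatter, and two pairs with no readable step are a weak test of transfer, saying nothing about a core outside these four compounds.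

Methyl and hydrogen are the only two groups seen on this carbon, so the compounds shown leave open what an ethyl group, an amine or a carboxylic acid would do there. They also leave open whether the swap would stay this quiet in any test other than this assay.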